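From fluoro to phenyl on the shared core

A few compounds are considered here, and "the series" means these few. Any claim that something is new, unique, unknown or untested is made for them only; others in the source may bear on it.

Compound 1 `COc1ccc(-c2cc3c(n2-c2ccc(O)c(C(=O)O)c2)CCCC3)cc1`: 173 mg/kg
Compound 2 `O=C(O)c1cc(-n2c(-c3ccc(F)cc3)cc3c2CCCC3)ccc1O`: 88 mg/kg

Going by the values given here, in a functional assay on the whole organism (strain Wistar) for inhibition, with Rattus norvegicus as the target, read by paw edema, with stated times of 30 min and 3 h (a higher number here means that more compound is needed for the effect, a lower number that less compound is needed), compound 2 gives 88 mg/kg, within the scatter of compound 1, the only other compound measured. Compound 3 `O=C(O)c1cc(-n2c(-c3ccc(-c4ccccc4)cc3)cc3c2CCCC3)ccc1O` carries phenyl in place of fluoro on an aromatic carbon, para to a large group: phenyl in place of fluoro on an aromatic carbon. Among the compounds with values here, the one measured step bearing on this change is a 2.0-fold lower number from compound 1 to compound 2 (0.29 log units; within the scatter), on that same carbon. Within the data shown here, no measured step brings a ring onto it, so the guide is weak. No step beyond the scatter is expected, in no firm direction, and the estimated change is a 1.1-fold higher number from compound 2 to compound 3 (0.06 log units; within the scatter). Compound 3 is expected at 100 mg/kg, within an estimated range from 40 mg/kg to 250 mg/kg.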

Compound 3, dose for half-maximal effect: 162 mg/kg
Compound 3: the middle estimate sits 1.6-fold (0.21 log units) below what was measured, and the stated range covers the measured number.
By their numbers in this assay, from the lowest: compounds 2, 3 and 1 (each within the scatter of the next).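

Going by these compounds alone, on this aromatic carbon, para to a large group, a whole phenyl ring now stands where the earlier compounds held only fluoro or methoxy, and in this assay that gives a 1.8-fold higher number from compound 2 to compound 3 (0.27 log units; within the scatter) and, against methoxy, a 1.1-fold lower number from compound 1 to compound 3 (0.03 log units; within the scatter). The position thus takes a group of six heavy atoms without any step beyond the scatter, so all three groups remain within the scatter of one another. No measured evidence bears on these numbers.

From the compounds shown here alone, whether an amine, a carboxylic acid or a longer chain on this carbon would give a step beyond the scatter stays open.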